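Dimethylamino for Fluoro on a Cytotoxicity Limit

The source may hold more compounds than are shown below. What is called first, only, known or untested is meant among the compounds shown, and "the series" means these compounds.

Compound 2 `Nc1nc(Cl)c(-c2nc3ccc(F)cc3s2)c(N[C@@H]2C[C@H](CO)[C@@H](O)[C@H]2O)n1` was tested in an ADME assay on cells (Homo sapiens) for cytotoxicity, read by polymerase chain reaction, with a stated time of 3 days; a lower number here means that less compound is tolerated, a higher number that more compound is tolerated. In this assay compound 2 reached only the limit of > 25000 nM. Compound 1 `Nc1nc(Cl)c(-c2ccco2)c(N[C@@H]2C[C@H](CO)[C@@H](O)[C@H]2O)n1` likewise gave only the limit of > 25000 nM. For the measured compounds named here, all that is known is the limit of > 25000 nM in this assay, at which 2 of the 2 values shown sit, so no step between measured compounds can be drawn. Compound 3 `CN(C)c1ccc2nc(-c3c(Cl)nc(N)nc3N[C@@H]3C[C@H](CO)[C@@H](O)[C@H]3O)sc2c1` differs from compound 2 by dimethylamino in place of fluoro on an aromatic carbon. Going by the values given here, with no measured step of this kind to lean on, the expected change is a step that the limit leaves unreadable from compound 2 to compound 3, nothing beyond the scatter. For compound 3 the expected value is 30000 nM, with a range from 8000 nM to 100000 nM.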

Compound 3, half-maximal cytotoxic concentration: > 25000 nM
Compound 3 ended at the assay's limit; the forecaster's own chance of this, stated with the estimate: 75%; the middle value is on the limit's open side.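

In this assay, compound 2 and compound 3 both stop at a limit rather than a number, so no step between them can be read: the limit of > 25000 nM in this assay, at which 3 of the 3 values shown sit.

The compounds shown leave open the concentration at which any of them becomes toxic to cells, and whether dimethylamino in place of fluoro changes it.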